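The compounds below may be only part of what the source reports. "The series", "measured", "known", "first", "only" and "open" are said of these compounds alone.

Measured compounds in an assay on microsomes from brain for inhibition of Fatty-acid amide hydrolase 1 (Rattus norvegicus), read by fluorescence and HPLC, with a stated time of 60 min; on this read-out lower numbers stand for stronger inhibition and higher numbers for weaker inhibition:
compound 1 `CCCCCCCCc1ccc(OCC(=O)Cn2nnc(-c3ccccc3)n2)cc1` gives 24 nM
compound 2 `CCCCCCCCc1ccc(OCC(=O)Cn2nnnc2-c2ccccc2Cl)cc1` gives 4600 nM
compound 3 `CCCCCCCCc1ccc(OC(C)C(=O)Cn2nnc(-c3ccccc3)n2)cc1` gives 24 nM

Compound 3 stands level with compound 1 at the digits shown, and both lie well away from compound 2, whose value is far weaker. Among the compounds with values here, the one step that connects two of these, no change at the digits printed from compound 1 to compound 3 (within the scatter), shows that the methyl on the chain carbon is tolerated.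

Compound 4 `CC(Oc1ccc(Oc2ccc(C(F)(F)F)cc2)cc1)C(=O)Cn1nnc(-c2ccccc2)n1` differs from compound 3 in another place: 4-(trifluoromethyl)phenoxy in place of octyl on an aromatic carbon. Within the data shown here, no measured step in this set touches that position; the only recorded change that stays within scatter concerns the chain carbon, and the large loss in compound 2 concerns the tetrazole attachment, so neither bears directly on the replacement of the octyl. The expectation for this assay therefore rests on compound 3 alone as the anchor, with a wide range in both directions. The step from compound 3 to compound 4 is estimated as a 1.5-fold higher number from compound 3 to compound 4 (0.16 log units; within the scatter). Compound 4 is expected to give 35 nM, within 5 nM to 250 nM.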

Compound 4, half-maximal inhibitory concentration: 160 nM
Beside the measured number, compound 4's estimate is 4.6-fold (0.66 log units) below it; the measured number falls inside the stated range.
By their numbers in this assay, from the lowest: compounds 1 and 3 (each within the scatter of the next); then compound 4; then compound 2.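

In this assay the aromatic carbon para to a large group proves sensitive to what it carries: 4-(trifluoromethyl)phenoxy in place of octyl gives a 6.7-fold higher number from compound 3 to compound 4 (0.82 log units; beyond the scatter) and so moves the read-out, unlike the methyl on the chain carbon with no change at the digits printed from compound 1 to compound 3 (within the scatter). Within the data shown here, the replacement, with its six-membered aromatic ring and added hydrogen-bond acceptor, costs inhibition without abolishing it, so octyl is not the only group accepted at this carbon. Nothing available accounts for the loss.

On these data alone, whether a plain phenoxy, a benzyloxy or a longer chain such as decyl would stay closer to compound 3 remains open. Also open, as far as these compounds go, is whether the 4-(trifluoromethyl)phenoxy group would give the same result with hydrogen in place of the methyl on the chain carbon.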